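Rearranging the linker in a metabotropic glutamate receptor 3 modulator

The source may hold more compounds than are shown below. What is called first, only, known or untested is meant among the compounds shown, and "the series" means these compounds.

Of the compounds shown here, three have been measured in an assay on HEK293 cells for positive allosteric modulation of metabotropic glutamate receptor 3 (Rattus norvegicus), read by thallium flux, with a stated time of 2.5 min; on this read-out higher numbers stand for larger maximal responses and lower numbers for smaller maximal responses. Compound 1, with the structure `Cc1c(OCCCCOCOc2ccc(C(=O)O)cc2)ccc(C(=O)CC2CCCC2)c1O`, gives 46.9% in this assay. Compound 2, `Cc1c(OCCCCOc2ccc(F)c(C(=O)O)c2)ccc(C(=O)CC(C)(C)C)c1O`, gives 102%, and compound 3, `Cc1c(OCCCCOc2ccc(C(=O)O)cc2)ccc(C(=O)CC(C)C)c1C`, gives 16.6%. Compound 1 thus stands second highest of the three: compound 3 lies closest to it, a number beyond the scatter lower, while compound 2 lies furthest, a number beyond the scatter higher.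

The unmeasured compound 4, `COc1ccc(C(=O)O)cc1OCCCCOc1ccc(C(=O)CC2CCCC2)c(O)c1C`, keeps the same atoms as compound 1 but joins them differently: 5-carboxy-2-methoxyphenyl in place of (4-carboxyphenoxy)methyl on an oxygen on a saturated carbon. Compound 1 and compound 4 differ in no other place, so the step between them is shown only through this rearrangement.

Going by the values given here, no pair among the measured compounds differs in just one place, so no measured step guides the expectation directly. The spread between compound 2 and compound 3 shows that direct aryl ethers can give both larger and smaller maximal responses than compound 1. An upward step is estimated for compound 4, expected as a number 18.1 percentage points higher from compound 1 to compound 4 (beyond the scatter) in this assay, larger than the usual scatter but uncertain. Compound 4 is expected to reach about 65% in this assay, with a range from 30% to 100%.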

Compound 4, largest response reached (reported as percent of maximum), in percent of the reference or control that the assay uses: 67.6%
Compound 4: the middle estimate sits 2.6 percentage points below what was measured; the measured number falls inside the stated range.
By their numbers in this assay, from the lowest: compound 3; then compound 1; then compound 4; then compound 2.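

In this assay, going by these compounds alone, the rearrangement gives the first measured step at this position, a number 20.7 percentage points higher from compound 1 to compound 4 (beyond the scatter). Within the data shown here, the two compounds hold the same atoms, so changing only how they are joined on this oxygen on a saturated carbon is enough to shift the maximal response beyond the usual scatter, which no earlier pair could show. No available data explain why the 5-carboxy-2-methoxyphenyl group gives the larger response than the (4-carboxyphenoxy)methyl group.

On these data alone, it remains open whether the methoxy group contributes to this rise, which a comparison with an ethoxy group or a plain hydrogen at the same place could test. It is also unknown whether the response would hold if a tetrazole replaced the carboxylic acid.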